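This account rests on a few compounds, and the source may have more. Where it says the series, first, only, none or still open, it means among the compounds named here.

Among the measured compounds shown here, in an assay on HEK293 cells for inhibition of diacylglycerol lipase-alpha (Homo sapiens), read by colorimetric assay, with stated times of 30 min, 60 s and 20 min (a higher number here means a weaker inhibitor, a lower number a stronger inhibitor), compound 1 `O=C(N1CCC=C[C@@H]1COCc1ccccc1)n1cc(-c2ccc(-c3ccccc3)cc2)nn1` gives 25.1 nM, the lowest of the three numbers so far. Compound 2 `O=C(N1CCC=C[C@H]1COCc1ccccc1)n1cc(-c2ccc(-c3ccccc3)cc2)nn1` gives 1260 nM; the step of a 50-fold higher number from compound 1 to compound 2 (1.70 log units; beyond the scatter) is large, and it arises because the fact that compounds 1 and 2 differ only in the configuration as drawn shows that the two compounds share every atom and bond and differ only at one saturated ring carbon. Compound 3 `O=C(N1C[C@@H](O)C=C[C@@H]1COCc1ccccc1)n1cc(-c2ccc(-c3ccccc3)cc2)nn1`, with a hydroxy in place of hydrogen on a saturated ring carbon, gives 31.6 nM, and the step of a 1.3-fold higher number from compound 1 to compound 3 (0.10 log units; within the scatter) stays within the scatter.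

Compound 4 `O=C(N1CCC=C[C@@H]1COCc1ccccc1)n1cc(-c2ccc([N+](=O)[O-])cc2)nn1` differs from compound 1 in a different region: nitro in place of phenyl on an aromatic carbon. Neither measured step concerns an aromatic carbon; both concern a saturated ring carbon, so neither offers a direct guide to this change. Replacing a whole ring by a much smaller group is, on general grounds, expected to weaken inhibition, that is, to raise the number. Compound 4 is therefore expected to give 160 nM in this assay, with a range from 30 nM to 900 nM. This estimate means an expected step of a 6.4-fold higher number from compound 1 to compound 4 (0.80 log units; beyond the scatter) that reaches beyond the scatter.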

Compound 4, half-maximal inhibitory concentration: 15.9 nM
The estimate for compound 4 lay 10-fold (1.00 log units) above the measured number; the measured number lies below the stated range.
By their numbers in this assay, from the lowest: compounds 4, 1 and 3 (each within the scatter of the next); then compound 2.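

With nitro in place of phenyl, the step of a 1.6-fold lower number from compound 1 to compound 4 (0.20 log units; within the scatter) in this assay shows that this aromatic carbon, para to a large group, can lose a whole six-membered aromatic ring of carbon only without a change beyond the scatter. The entering group has 3 heavy atoms where the leaving group has 6, and 2 hydrogen-bond acceptors where the leaving group has 0, so inhibition at this position does not depend on keeping the phenyl ring. The compounds shown give no reason for this match.

One pair cannot say whether other groups at this carbon would behave in the same way. From the compounds shown here alone, it remains open what an amine, a carboxylic acid or a chlorine atom would do here, and whether nitro would give the same result alongside the hydroxy of compound 3 or the configuration of compound 2.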